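This account rests on a few compounds, and the source may have more. Where it says the series, first, only, none or still open, it means among the compounds named here.

Measured so far: compound 1 `COc1ccc2c(O[C@@H]3C[C@H]4C(=O)N[C@]5(C(=O)NS(=O)(=O)C6CC6)C[C@H]5/C=C\CCCCCNC(=O)N4C3)cc(-c3nc(C(C)C)cs3)nc2c1`, 5220 ng.h/mL; compound 2 `COc1ccc2c(O[C@@H]3C[C@H]4C(=O)N[C@]5(C(=O)NS(=O)(=O)C6CC6)C[C@H]5/C=C\CCCCNC(=O)N4C3)cc(-c3nc(C(C)C)cs3)nc2c1`, 2170 ng.h/mL.

Both numbers come from an ADME assay on the whole organism (plasma, strain Sprague-Dawley) for pharmacokinetics, with Rattus norvegicus as the target, at a dose of 2 mg/kg by the intravenous route; a higher number here means more compound in the circulation at the dose given, a lower number less compound in the circulation. Compound 2 stands lowest of the two; compound 1 gives the higher number, and that gap lies beyond the scatter. Compound 3 `COc1ccc2c(O[C@@H]3C[C@H]4C(=O)N[C@]5(C(=O)NS(=O)(=O)C6CC6)C[C@H]5/C=C\CCCCN(C)C(=O)N4C3)cc(-c3nc(C(C)C)cs3)nc2c1` differs from compound 2 by methyl in place of hydrogen on an amide-type nitrogen in a ring. Going by the values given here, no measured pair shows this change, so nothing here fixes its size or direction; the step is expected to stay within the scatter: a 1.1-fold lower number from compound 2 to compound 3 (0.04 log units; within the scatter). Compound 3 is estimated at 2000 ng.h/mL, with a range of 900 ng.h/mL to 4500 ng.h/mL.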

Compound 3, area under the concentration-time curve: 1220 ng.h/mL
Compound 3: middle estimate off by 1.6-fold (0.21 log units), on the high side, and the stated range covers the measured number.
By their numbers in this assay, from the lowest: compounds 3 and 2 (each within the scatter of the next); then compound 1.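

In this assay, going by these compounds alone, methyl in place of hydrogen on the amide-type nitrogen in the ring gives a 1.8-fold lower number from compound 2 to compound 3 (0.25 log units; within the scatter), the first reading of this change at this position. The step does not separate compound 3 from compound 2, so this nitrogen can carry a methyl without a shift beyond the scatter. Nothing available explains the step.

From the compounds shown here alone, whether ethyl, a longer chain or an acetyl on this nitrogen would stay within the scatter remains open. So does the size of the methyl step on compound 1.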